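Removing a saturated-ring methyl from the bicyclic amide series

A few compounds are considered here, and "the series" means these few. Any claim that something is new, unique, unknown or untested is made for them only; others in the source may bear on it.

Three compounds sharing the carboxamide core have numbers in an assay on K562 cells for inhibition of Nicotinamide N-methyltransferase (Homo sapiens), read by mass spectrometry, with a stated time of 24 h; a lower number here means a stronger inhibitor, a higher number a weaker inhibitor. Compound 1 `CNc1cc(C)c(C(N)=O)cn1` gives 25 nM. Compound 2 `Cc1c(C(N)=O)cnc2c1CCN2`, in which the core is closed into a fused five-membered ring, gives 23 nM; compounds 1 and 2 lie within the scatter of each other. Compound 3 `C[C@H]1Nc2ncc(C(N)=O)cc2[C@@H]1C` carries two methyl groups on the saturated ring and gives 114 nM, the highest number of the three, beyond the scatter from both compound 1 and compound 2.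

Compound 4 `C[C@@H]1Cc2cc(C(N)=O)cnc2N1` is the next member. The counted difference from compound 3 is hydrogen in place of methyl on a saturated ring carbon.

For the measured compounds named here, no measured pair differs in only this place, so the size of the step is open. Going by the values given here, the only guide is that compound 3, the sole member with substituents on the saturated ring, sits well above compounds 1 and 2. Taking one of those substituents away is expected to bring the number part of the way back toward compound 2, a step of a 2.1-fold lower number from compound 3 to compound 4 (0.32 log units; beyond the scatter) in this assay, though a step within the scatter cannot be excluded. Compound 4 is estimated at 55 nM, with a range from 22 nM to 140 nM.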

Compound 4, half-maximal inhibitory concentration: 38 nM
Estimate against measurement, compound 4: 1.4-fold (0.16 log units) above; low and high end bracket the measured number.
By their numbers in this assay, from the lowest: compounds 2, 1 and 4 (each within the scatter of the next); then compound 3.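

In this assay, for the compounds shown here, this is the first pair that differs in only one place, and it puts a size on the change: hydrogen in place of methyl on this saturated ring carbon gives a 3.0-fold lower number from compound 3 to compound 4 (0.48 log units; beyond the scatter). Compound 4 still carries a methyl group on the saturated ring and gives 38 nM, against the printed 114 nM for compound 3, so within this pair the higher number goes with the second methyl group and not with the presence of any substituent on that ring. The data offer no measured explanation for why this single methyl group changes the number.

As far as these compounds go, it remains open whether an ethyl group, a hydroxyl group or a fluorine atom on this saturated ring carbon would give a number closer to that of compound 3 or compound 4. From the compounds shown here alone, the result also rests on one pair, so it is open whether the same change would give a step of similar size with the other ring methyl group replaced by hydrogen.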